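Swapping a Fluorinated Chain for an Aminocyclohexyl Ring

The compounds below may be only part of what the source reports. "The series", "measured", "known", "first", "only" and "open" are said of these compounds alone.

Measured compounds:
Compound 1 `C/C(CN(C[C@H]1Cc2ccccc2CN1)[C@H]1CCCc2cccnc21)=C(\F)CN` gives 550 nm/s in an ADME assay for permeability, using PAMPA, with a stated time of 4 h, at pH 7.4; on this read-out lower numbers stand for lower permeability and higher numbers for higher permeability.
Compound 2 `C/C(CN)=C(/F)CN(C[C@H]1Cc2ccccc2CN1)[C@H]1CCCc2cccnc21` gives 220 nm/s in this assay.

Compound 2 has the lower of the two numbers, with a 2.5-fold lower number from compound 1 to compound 2 (0.40 log units; beyond the scatter), a modest step beyond the usual scatter. Compound 3 `N[C@H]1CC[C@H](N(C[C@H]2Cc3ccccc3CN2)[C@H]2CCCc3cccnc32)CC1` differs from compound 2 by 4-aminocyclohexyl in place of 3-(aminomethyl)-2-fluorobut-2-en-1-yl on an amine nitrogen. For the measured compounds named here, no measured step bears directly on this replacement: the only step, a 2.5-fold lower number from compound 1 to compound 2 (0.40 log units; beyond the scatter), rearranges the same chain rather than exchanging it for a ring. With no guide, compound 3 is expected to sit close to compound 2, with a 1.1-fold lower number from compound 2 to compound 3 (0.04 log units; within the scatter) not beyond the scatter. Compound 3 is therefore estimated at 200 nm/s, within a range from 80 nm/s to 500 nm/s.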

Compound 3, apparent permeability: 37 nm/s
Beside the measured number, compound 3's estimate is 5.4-fold (0.73 log units) above it; measured number outside the range, below it.
By their numbers in this assay, from the lowest: compound 3; then compound 2; then compound 1.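

At this amine nitrogen, the group can move the number much further than the earlier pair showed: in this assay, 4-aminocyclohexyl gives a 5.9-fold lower number from compound 2 to compound 3 (0.77 log units; beyond the scatter) and a 15-fold lower number from compound 1 to compound 3 (1.17 log units; beyond the scatter) against the two fluorinated chains. The entering and leaving groups match in heavy atoms and hydrogen-bond donors, so those counts alone do not separate them here. Nothing available explains the drop. The ring and the loss of fluorine change together, so their contributions remain unseparated. Going by these compounds, whether a plain cyclohexyl or a straight aminobutyl chain would sit nearer compound 3 also remains open.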